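Replacing a Hydroxy Group: Cytotoxicity Outlook for Compound 3

The source may hold more compounds than are shown below. What is called first, only, known or untested is meant among the compounds shown, and "the series" means these compounds.

Compound 1, `CCCCCCCCCO[C@@H]1[C@@H](N)[C@@H](OCC(O)CNCCO)O[C@H](CN)[C@H]1OCCCCCCCCC`: 99.1%
Compound 2, `NC[C@H]1O[C@H](O[C@H]2[C@H](O)[C@@H](O)[C@H](N)C[C@@H]2N)[C@H](N)[C@@H](OCc2ccc3ccccc3c2)[C@@H]1OCc1ccc2ccccc2c1`: 79.1%

In a toxicity assay on the whole organism (J774 cells) for cytotoxicity, with Mus musculus as the target, read by MTT assay, with a stated time of 24 h, tested at 10 uM (a higher number here means a weaker effect of the compound at the concentration tested, a lower number a stronger effect), compound 1 gives 99.1%, the highest of the two numbers. Compound 2 gives 79.1%, a value lower by more than the scatter; the two structures differ in several places, so no single step can be read from them. Compound 3, `CCCCCCCCCO[C@@H]1[C@@H](N)[C@@H](OCC(O)CNCCCN)O[C@H](CN)[C@H]1OCCCCCCCCC`, differs from compound 1 by aminomethyl in place of hydroxy on a saturated chain carbon, two bonds along the chain from an amine nitrogen. Within the data shown here, no measured pair isolates this change, so compound 3 is expected to show no step beyond the scatter, a number 4.1 percentage points lower from compound 1 to compound 3 (within the scatter). Compound 3 is estimated at 95%, within a range from 80% to 102%.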

Compound 3, a percentage reported as activity, at one concentration (the size of the read-out at that concentration, not a potency): 101%
Estimate against measurement, compound 3: 6 percentage points below; measured number inside the range.
By their numbers in this assay, from the lowest: compound 2; then compounds 1 and 3 (each within the scatter of the next).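

In this assay, among these compounds, the step at this position is a number 1.9 percentage points higher from compound 1 to compound 3 (within the scatter), the first reading of aminomethyl in place of hydroxy on a saturated chain carbon, two bonds along the chain from an amine nitrogen. At this place on the core of compound 1, the swap therefore gives no difference that can be told from the scatter. No available evidence bears on this result.

As far as these compounds go, whether a carboxylic acid or a longer chain ending in an amine would also stay within the scatter at this place remains open. So does whether the same swap would read alike on the core of compound 2.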